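The source may hold more compounds than are shown below. What is called first, only, known or untested is meant among the compounds shown, and "the series" means these compounds.

Measured so far:
- compound 1, `Cc1cc(C)n(-c2nc(C)c(-c3ccccc3)c(=O)[nH]2)n1`: 9000 nM
- compound 2, `CCc1cc(C)nn1-c1nc(C(F)(F)F)cc(=O)[nH]1`: 108000 nM

Both compounds were tested in an ADME assay on CHO cells (Cricetulus griseus) for cytotoxicity, read by MTT assay; a lower number here means a stronger inhibitor, a higher number a weaker inhibitor. Compound 1 gives 9000 nM, and compound 2 gives 108000 nM, the higher of the two numbers; the gap between them lies beyond the usual scatter, so compound 2 is the weaker of the pair in this assay. The two structures differ in more than one place, so no single change can be tied to that gap.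

Compound 3, `Cc1cc(NC2CCOCC2)n(-c2nc(C(F)(F)F)cc(=O)[nH]2)n1`, has not yet been measured. It differs from compound 2 in one place: (oxan-4-yl)amino in place of ethyl on an aromatic carbon. With only two measured compounds and no single-change step between them, there is no shown step to guide the direction. The step from compound 2 to compound 3 is expected to be small, a 1.4-fold lower number from compound 2 to compound 3 (0.13 log units; within the scatter), and not clearly beyond the scatter. Compound 3 is therefore estimated at 80000 nM, between 20000 nM and 300000 nM.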

Compound 3, half-maximal inhibitory concentration in the CHO assay: 18000 nM
Estimate against measurement, compound 3: 4.4-fold (0.65 log units) above; the measured number lies below the stated range.
By their numbers in the CHO assay, from the lowest: compounds 1 and 3 (each within the scatter of the next); then compound 2.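

In the CHO assay, (oxan-4-yl)amino in place of ethyl on an aromatic carbon next to the ring nitrogen gives a 6.0-fold lower number from compound 2 to compound 3 (0.78 log units; beyond the scatter). Among these compounds, this is the first single-change step, and it shows that the number in this assay responds to what this position carries, with the larger group giving the stronger inhibitor of the pair. In a physicochemical assay for solubility, at pH 7.4 (on this read-out higher numbers stand for higher solubility and lower numbers for lower solubility), compound 2 gives 200000 nM, and compound 3 gives 50000 nM. The same change also lowers solubility, read in the physicochemical assay: the measured solubility of compound 2, 200000 nM, and of compound 3, 50000 nM, a 4.0-fold lower number (0.60 log units; beyond the scatter)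

One pair cannot separate the part played by the six-membered ring from that of the nitrogen joining it to the core, so a plain amino group or a cyclohexylamino group at this position would be needed to pull them apart. From the compounds shown here alone, it also remains open whether the same change would give a similar step on the core of compound 1.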